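Cytotoxicity of Three Measured Analogues and One Untested Compound

This account rests on a few compounds, and the source may have more. Where it says the series, first, only, none or still open, it means among the compounds named here.

Compound 1 `COc1nc2ccc(Br)cc2cc1C(c1ccccc1)n1cc(-c2ccc(Br)cc2)nn1`: 6.28%
Compound 2 `COc1nc2ccc(Br)cc2cc1C(c1ccccc1)n1cc(-c2ccc(OC(F)(F)F)cc2)nn1`: 5.8%
Compound 3 `COc1nc2ccc(Br)cc2cc1C(c1ccccc1)n1cc(-c2ccc(F)cc2)nn1`: 4.04%

Three compounds were tested in an ADME assay on HEK293 cells (Homo sapiens) for cytotoxicity, read by sulforhodamine B assay, with a stated time of 48 h, tested at 10 uM; a lower number here means less inhibition, a higher number more inhibition at the concentration tested (going by the name of the read-out). In that test compound 1 gives 6.28%, compound 2 gives 5.8% and compound 3 gives 4.04%. Compound 2 stands second highest of the three; its nearest neighbour is compound 1, with a number 0.5 percentage points lower from compound 1 to compound 2 (within the scatter), and its furthest is compound 3, with a number 1.8 percentage points lower from compound 2 to compound 3 (within the scatter). The remaining step, a number 2.2 percentage points lower from compound 1 to compound 3 (within the scatter), is likewise within the scatter, so the three values cannot be told apart.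

Compound 4 `COc1nc2ccc(Br)cc2cc1C(c1ccccc1)n1cc(CCO)nn1` has not been measured. It differs from compound 2 by 2-hydroxyethyl in place of 4-(trifluoromethoxy)phenyl on an aromatic carbon. For the measured compounds named here, none of the measured steps bears directly on this change: each of them exchanges one group on the phenyl ring for another, and every one of them was within the scatter. With all three measured values at a similar level and no step beyond the scatter anywhere, the expectation for compound 4 is a step of a number 0.3 percentage points lower from compound 2 to compound 4 (within the scatter), that is, no change beyond the scatter. Compound 4 is therefore estimated at 5.5%, with a range from 0% to 15%.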

Compound 4, a percentage reported as inhibition, at one concentration (the size of the read-out at that concentration, not a potency): 4.54%
Compound 4: middle estimate off by 1 percentage points, on the high side; low and high end bracket the measured number.
By their numbers in this assay, from the lowest: compounds 3, 4, 2 and 1 (each within the scatter of the next).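

For the compounds shown here, on the aromatic carbon of the five-membered ring, the earlier compounds changed only the group on the phenyl ring, whereas compound 4 replaces the whole aryl group with 2-hydroxyethyl. This much larger exchange gives a number 1.3 percentage points lower from compound 2 to compound 4 (within the scatter) and a number 0.5 percentage points higher from compound 3 to compound 4 (within the scatter) and also a number 1.7 percentage points lower from compound 1 to compound 4 (within the scatter) in this assay at this position. A group with no ring and with a hydrogen-bond donor therefore cannot be told apart here from the three aryl groups, and no evidence is available to explain this.

Whether an amine, a carboxylic acid or a longer chain on this carbon would also stay within the scatter remains open, as 2-hydroxyethyl is the only group without a ring shown here. The compounds also leave open whether these values would hold at a higher concentration.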